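This account rests on a few compounds, and the source may have more. Where it says the series, first, only, none or still open, it means among the compounds named here.

In a functional assay on MCF-A cells (Homo sapiens) for cytotoxicity (on this read-out lower numbers stand for stronger inhibition of growth and higher numbers for weaker inhibition of growth), compound 3 `CSc1ccc(C2=C(c3ccc(C)c(C)c3)C(=O)N3CCCC3C2)cc1` gives 800 nM. Compound 2 `CSc1ccc(C2=C(c3ccc(F)c(F)c3)C(=O)N3CCCC3C2)cc1` gives 800 nM and compound 1 `COc1ccc(C2=C(c3ccc(SC)cc3)CC3CCCN3C2=O)cc1C` gives 400 nM, so all three lie within the scatter of one another. Compound 4 `CSc1ccc(C2=C(c3ccc(O)c(O)c3)C(=O)N3CCCC3C2)cc1` has 3,4-dihydroxyphenyl in place of 3,4-dimethylphenyl on a double-bonded ring carbon. Three measured steps alter the aromatic group at this place: no change at the digits printed from compound 2 to compound 3 (within the scatter), a 2.0-fold higher number from compound 1 to compound 3 (0.30 log units; within the scatter) and a 2.0-fold higher number from compound 1 to compound 2 (0.30 log units; within the scatter). Among the measured compounds shown here, no measured compound carries 3,4-dihydroxyphenyl, so this evidence is indirect. No step beyond the scatter is therefore expected in this assay. The estimated step is a 1.3-fold higher number from compound 3 to compound 4 (0.10 log units; within the scatter). For compound 4 the estimated value is 1000 nM, with an expected range from 300 nM to 4000 nM.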

Compound 4, concentration for 50% growth inhibition: 80000 nM
Compound 4: the middle estimate sits 80-fold (1.90 log units) below what was measured; the measured number lies above the stated range.
By their numbers in this assay, from the lowest: compounds 1, 2 and 3 (each within the scatter of the next); then compound 4.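

The aromatic groups of compound 1, compound 2 and compound 3 on the double-bonded ring carbon had stayed within the scatter of one another, so this place had seemed indifferent to the change of group in this assay. The 3,4-dihydroxyphenyl group shows that it is not, with a 100-fold higher number from compound 3 to compound 4 (2.00 log units; beyond the scatter) and a 100-fold higher number from compound 2 to compound 4 (2.00 log units; beyond the scatter) and also a 200-fold higher number from compound 1 to compound 4 (2.30 log units; beyond the scatter) as the large steps that it brings. Nothing measured here accounts for this rise. On these data alone, whether one hydroxy group alone would bring such a step stays open, as does what 3,4-dimethoxyphenyl or an aminophenyl group would give at this place.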